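The source may report more compounds than this note shows. Statements on the series, on what has been measured and on what is new or still open speak of the compounds shown alone.

Measured in a functional assay on MCF7 cells (Homo sapiens) for cytotoxicity, read by MTT assay, with a stated time of 72 h; a lower number here means a stronger inhibitor, a higher number a weaker inhibitor:
- compound 1 `O=C1C(=Cc2ccc(Cl)cc2Cl)C(=O)N(c2ccc(Cl)cc2)N1c1ccc(Cl)cc1`: > 128000 nM (a limit of the assay)
- compound 2 `O=C1C(=Cc2ccco2)C(=O)N(c2ccc(Cl)cc2)N1c1ccc(Cl)cc1`: 20300 nM

Among the measured compounds shown here, compound 2 holds the only true number so far. For compound 1 there is only (the limit of > 128000 nM in this assay, at which 1 of the 2 values shown sits). For the measured compounds named here, the single measured step at this place is an at least 6.3-fold lower number from compound 1 to compound 2 (0.79 log units; beyond the scatter), with furan-2-yl in place of 2,4-dichlorophenyl. Compound 3 `O=C1C(=C/C=C/c2ccccc2)C(=O)N(c2ccc(Cl)cc2)N1c1ccc(Cl)cc1` puts 2-phenylethenyl in place of furan-2-yl on a double-bonded chain carbon bound to a double-bonded ring carbon. This brings back a six-membered aromatic ring, so part of an at least 6.3-fold lower number from compound 1 to compound 2 (0.79 log units; beyond the scatter) is expected to be lost. The expected change is modest and uncertain, an estimated 2.0-fold higher number from compound 2 to compound 3 (0.29 log units; within the scatter). For compound 3 the estimate is 40000 nM, with an expected range of 10000 nM to 128000 nM.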

Compound 3, half-maximal inhibitory concentration: 9400 nM
Beside the measured number, compound 3's estimate is 4.3-fold (0.63 log units) above it, and the stated range ends above it.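

In this assay, the place on the double-bonded chain carbon accepts a six-membered aromatic ring of carbon only: 2-phenylethenyl in place of furan-2-yl gives a 2.2-fold lower number from compound 2 to compound 3 (0.33 log units; beyond the scatter). Such a ring alone therefore does not mark a weak compound, and 2-phenylethenyl in place of 2,4-dichlorophenyl gives an at least 13-fold lower number from compound 1 to compound 3 (1.13 log units; beyond the scatter). Compound 1 has only a limit of the assay: the limit of > 128000 nM in this assay, at which 1 of the 3 values shown sits.

As far as these compounds go, whether the ring or the double bond of 2-phenylethenyl carries this change stays open. So does the effect of an amine or a carboxylic acid on that ring, or of a saturated 2-phenylethyl chain.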